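This account rests on a few compounds, and the source may have more. Where it says the series, first, only, none or still open, it means among the compounds named here.

Compound 1 `O=C(NCCCCc1ccccc1)n1cc(-c2ccccc2)oc1=O`: < 0.0834 h
Compound 2 `CC(C)CNC(=O)n1cc(-c2ccccc2)oc1=O`: > 2 h
Compound 3 `COc1cc(-c2cn(C(=O)NCCCCc3ccccc3)c(=O)o2)ccc1F`: not yet measured

The measurements come from an ADME assay on a cell-free system (plasma, Mus musculus) for metabolic stability, read by LC-MS, tested at 2 uM; a lower number here means that the compound disappears faster, a higher number that the compound lasts longer. There, compound 1 gives < 0.0834 h, which is a limit of the assay and not a number. Compound 2 gives > 2 h, also a limit. Of the two, compound 1 stands at the short-lived end.

Compound 3 carries 4-fluoro-3-methoxyphenyl in place of phenyl on an aromatic carbon, next to the ring oxygen (4-fluoro-3-methoxyphenyl in place of phenyl on an aromatic carbon). Going by the values given here, no measured pair shows the size of such a change. Compound 3 keeps the rest of compound 1, so the expectation in this assay starts from compound 1 at < 0.0834 h, a limit. No change beyond the scatter is expected, and the estimated move is a step that the limit leaves unreadable from compound 1 to compound 3. For compound 3 the estimated half-life is 0.08 h, with an expected range of 0.03 h to 0.3 h.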

Compound 3, half-life: > 2 h
Compound 3: no number, only a limit (the forecaster's own chance of this, stated with the estimate: 60%); middle value at least 25-fold (1.39 log units) from the limit.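

In this assay, 4-fluoro-3-methoxyphenyl in place of phenyl on the aromatic carbon next to the ring oxygen gives an at least 23-fold higher number from compound 1 to compound 3 (1.37 log units; beyond the scatter), the first sign from any pair shown that this position can decide how long a compound lasts. Compound 3 keeps the rest of compound 1, so that remainder alone does not fix the short half-life of compound 1. Compound 3 stands at a limit of the assay, so the step marks a floor and not a full size: the limit of > 2 h in this assay, at which 2 of the 3 values shown sit.

The fluorine and the methoxy group enter together, and the compounds shown do not separate them. From the compounds shown here alone, whether 4-fluorophenyl or 3-methoxyphenyl alone would give the same step remains open, as does the outcome with an amine on that ring.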